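Second Trifluoromethyl Group and Cell Toxicity: An Expected Result

A few compounds are considered here, and "the series" means these few. Any claim that something is new, unique, unknown or untested is made for them only; others in the source may bear on it.

Measured compounds:
compound 1 `Cc1cc(NC(=O)c2cccc(C(F)(F)F)c2)ccc1NS(C)(=O)=O`: 110000 nM
compound 2 `Cc1cc(NC(=O)c2cc(C(F)(F)F)cc(C(F)(F)F)c2)ccc1NS(C)(=O)=O`: > 250000 nM
compound 3 `CCS(=O)(=O)Nc1ccc(NC(=O)c2cccc(C(F)(F)F)c2)cc1Cl`: 62400 nM

These three were tested in an ADME assay on RAW264.7 cells (Mus musculus) for cytotoxicity, read by MTT assay, with a stated time of 48 h; on this read-out higher numbers stand for weaker inhibition and lower numbers for stronger inhibition. Compound 1 gives 110000 nM. For compound 2 this assay reports only a limit, > 250000 nM, which is the limit of > 250000 nM in this assay, at which 1 of the 3 values shown sits. Compound 3 gives 62400 nM. The difference between the two cores of compound 1 and compound 3 is not broken down here.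

Compound 2 differs from compound 1 by trifluoromethyl in place of hydrogen on an aromatic carbon. The step this made was an at least 2.2-fold higher number from compound 1 to compound 2 (0.35 log units; beyond the scatter).

Compound 4 `CCS(=O)(=O)Nc1ccc(NC(=O)c2cc(C(F)(F)F)cc(C(F)(F)F)c2)cc1Cl` has not yet been measured. It differs from compound 3 by trifluoromethyl in place of hydrogen on an aromatic carbon, the same change as from compound 1 to compound 2. Because the earlier step was an at least 2.2-fold higher number from compound 1 to compound 2 (0.35 log units; beyond the scatter), a step of similar size is expected from compound 3 to compound 4, namely a 2.6-fold higher number from compound 3 to compound 4 (0.41 log units; beyond the scatter). Compound 4 is therefore estimated at 160000 nM, expected to lie between 80000 nM and 300000 nM.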

Compound 4, half-maximal inhibitory concentration: 64100 nM
The estimate for compound 4 lay 2.5-fold (0.40 log units) above the measured number; measured number outside the range, below it.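

In this assay, going by these compounds alone, trifluoromethyl in place of hydrogen on an aromatic carbon gave a 1.0-fold higher number from compound 3 to compound 4 (0.01 log units; within the scatter), so on this core the change produced no step that can be told from the scatter. This does not show that the change carries differently from one core to the other, and two cores cannot set a rule for the series: the same change on two cores in this assay, an at least 2.2-fold higher number (0.35 log units; beyond the scatter) from compound 1 to compound 2 and a 1.0-fold higher number (0.01 log units; within the scatter) from compound 3 to compound 4; the limit leaves it open whether they differ The value of compound 2 is a limit and not a number: the limit of > 250000 nM in this assay, at which 1 of the 4 values shown sits.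

The compounds shown leave open how a nitrile, an amine or a carboxylic acid in that place would read in this assay. They also leave open whether a third core would follow compound 3 and compound 4 or the earlier pair.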